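The compounds below may be only part of what the source reports. "The series", "measured", "known", "first", "only" and "open" are said of these compounds alone.

In a toxicity assay on NIH3T3 cells (Mus musculus) for cytotoxicity, read by resazurin assay (on this read-out lower numbers stand for an effect already at smaller amounts and higher numbers for an effect only at larger amounts of compound), compound 1 `c1ccc(-c2ccc(Cn3cncc3CNc3cccc(-c4ccccc4)c3)cc2)cc1` gives 10000 nM and compound 2 `O=[N+]([O-])c1ccc(Cn2cncc2CNc2cccc(-c3ccccc3)c2)cc1` gives 10000 nM. Nitro in place of phenyl on an aromatic carbon shows no change at the digits printed from compound 1 to compound 2 (within the scatter). Compound 3 `c1ccc(Cn2cncc2CNc2cccc(-c3ccccc3)c2)cc1` has only a limit, > 750 nM. Hydrogen in place of phenyl gives a step that the limit leaves unreadable from compound 1 to compound 3, and hydrogen in place of nitro gives a step that the limit leaves unreadable from compound 2 to compound 3, so compound 3 has no exact position relative to the other two.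

Compound 4 `Cc1ccc(Cn2cncc2CNc2cccc(-c3ccccc3)c2)cc1` carries methyl in place of hydrogen on an aromatic carbon, para to a large group: methyl in place of hydrogen on an aromatic carbon. Among the measured compounds shown here, only one measured step at this carbon has a readable size, no change at the digits printed from compound 1 to compound 2 (within the scatter), and it stays within the scatter. On that basis, this assay is expected to show no large effect from the methyl, with compound 4 remaining in the high range of compound 1 and compound 2. The expected step is a step that the limit leaves unreadable from compound 3 to compound 4, though its true size remains uncertain. Compound 4 is estimated at 6000 nM, with an expected range of 1500 nM to 15000 nM.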

Compound 4, half-maximal effective concentration: 10000 nM
Compound 4: the middle estimate sits 1.7-fold (0.22 log units) below what was measured, and the stated range covers the measured number.
By their numbers in this assay, from the lowest: compounds 1, 2 and 4 (each within the scatter of the next).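

In this assay, methyl in place of nitro shows no change at the digits printed from compound 2 to compound 4 (within the scatter), and methyl in place of phenyl shows no change at the digits printed from compound 1 to compound 4 (within the scatter). Among the compounds shown here, with methyl, a third group now sits on this aromatic carbon with no readable difference from the other two, where earlier only the pair of phenyl and nitro could be compared. Compound 3, which carries hydrogen on this carbon, has only a limit, so the steps that involve it, including the new one to compound 4, cannot be read: the limit of > 750 nM in this assay, at which 1 of the 4 values shown sits.

Going by these compounds, whether the plain benzyl of compound 3 stands level with the 4-methylbenzyl of compound 4 therefore remains open. Also open, on these data alone, is whether an amine or a carboxylic acid on this carbon would shift the number in this assay at all.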